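This account rests on a few compounds, and the source may have more. Where it says the series, first, only, none or still open, it means among the compounds named here.

Measured so far in a functional assay on UACC-62 cells (Homo sapiens) for cytotoxicity, read by sulforhodamine B assay, with a stated time of 48 h; on this read-out higher numbers stand for lower toxicity in this test and lower numbers for higher toxicity in this test:
compound 1 `ClCc1ccccc1Cn1cnc2c(Cl)nc(Cl)nc21` gives 5240 nM;
compound 2 `ClCc1ccc(Cn2cnc3nc(Cl)nc(Cl)c32)cc1` gives 6020 nM;
compound 3 `ClCc1ccccc1Cn1cnc2ncnc(Cl)c21` gives 19100 nM.

Compound 3 stands highest of the three in this assay, and its gap to compound 2 and to compound 1 lies beyond the usual scatter, so it is the least toxic of the measured set. Compound 4 `ClCc1ccccc1Cn1cnc2nc(Cl)nc(Cl)c21` differs from compound 3 by chloro in place of hydrogen on an aromatic carbon. For the measured compounds named here, no step between measured compounds isolates this change. Both compound 1 and compound 2 carry two chloro groups on the core and sit lower than compound 3, so the estimate for compound 4 expects a step downward beyond the scatter, of about a 2.9-fold lower number from compound 3 to compound 4 (0.47 log units; beyond the scatter). Compound 4 is therefore estimated at 6500 nM in this assay, in the range 3000 nM to 14000 nM.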

Compound 4, concentration lethal to 50% of the cells: 6760 nM
For compound 4 the middle estimate is 1.0-fold (0.02 log units) below the measured one; the measured number falls inside the stated range.
By their numbers in this assay, from the lowest: compounds 1, 2 and 4 (each within the scatter of the next); then compound 3.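

In this assay, for the compounds shown here, chloro in place of hydrogen on an aromatic carbon between two ring nitrogen atoms gives a 2.8-fold lower number from compound 3 to compound 4 (0.45 log units; beyond the scatter) and so provides the first isolated reading of this change. The step lies beyond the scatter, so in this one pair the added chloro goes with higher toxicity in this test. Nothing at hand bears on what lies behind this step.

From the compounds shown here alone, whether an amine or a methoxy group on the same carbon would move the number the same way stays open. So does whether the step recurs in another pair.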